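A few compounds are considered here, and "the series" means these few. Any claim that something is new, unique, unknown or untested is made for them only; others in the source may bear on it.

In an assay on HUVEC cells for inhibition of transcription factor p65 (Homo sapiens) (on this read-out higher numbers stand for larger maximal responses and lower numbers for smaller maximal responses), compound 1 `Cc1ccc2cccc(NS(=O)(=O)c3ccc(C(F)(F)F)cc3[N+](=O)[O-])c2n1` sits at the limit > 90%.
In this assay compound 2 `COc1cc(NS(=O)(=O)c2ccc(C)cc2[N+](=O)[O-])c2nc(C)ccc2c1` sits at the limit > 90%.
In this assay compound 3 `COc1cc(NS(=O)(=O)c2ccc(C)cc2)c2nc(C)ccc2c1` sits at the limit > 90%.

Compound 3 therefore stands at the limit together with the other two, (the limit of > 90% in this assay, at which 3 of the 3 values shown sit), and nothing in the numbers sets it apart from compound 1 or compound 2. For the measured compounds named here, the only step between measured compounds, from compound 2 to compound 3 a step that the two limits leave unreadable from compound 2 to compound 3, gives no size. Compound 4 `COc1cc(NS(=O)(=O)c2ccc(C)cc2N)c2nc(C)ccc2c1` differs from compound 3 by amino in place of hydrogen on an aromatic carbon. Going by the values given here, no measured step touches an amino group, so nothing bears on this change beyond the fact that every compound so far reached the limit. The expected step that the limit leaves unreadable from compound 3 to compound 4 in this assay is none beyond the scatter. Compound 4 is estimated to give 92%, between 75% and 100%.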

Compound 4, largest response reached (reported as efficacy), in percent of the reference or control that the assay uses: > 90%
Compound 4 ended at the assay's limit; the forecaster's own chance of this, stated with the estimate: 75%; the middle value is on the limit's open side.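

Compound 4 gives > 90% in this assay, which is a limit, so no step from compound 2 or compound 3 to compound 4 can be read: the limit of > 90% in this assay, at which 4 of the 4 values shown sit.

The compounds shown leave open whether nitro, amino or hydrogen at this place changes the largest response at all.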